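Adding a methyl to the side chain of compound 3

The compounds below may be only part of what the source reports. "The series", "measured", "known", "first", "only" and "open" are said of these compounds alone.

Compounds 2 and 3 share one core and differ only in the chain on their amide carbonyl. In a functional assay on MCF7 cells (Homo sapiens) for antiproliferative activity, read by MTT assay, with a stated time of 72 h (a higher number here means a weaker inhibitor, a lower number a stronger inhibitor), compound 2 `C/C=C/C(=O)Nc1cccc(Oc2nc(Nc3cccc(OC)c3)nc3c2CSCC3)c1` gives 23400 nM and compound 3 `CC/C=C/C(=O)Nc1cccc(Oc2nc(Nc3cccc(OC)c3)nc3c2CSCC3)c1` gives 24200 nM, so the two sit level with each other. Compound 1 `CC(C)/C=C/C(=O)Nc1cccc(Oc2nc(Nc3ccn(C)n3)nc3c2CSCC3)c1` is reported in this assay only as a limit, > 50000 nM. That leaves compound 3 with a single numerical neighbour, compound 2.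

The next compound is compound 4 `COc1cccc(Nc2nc3c(c(Oc4cccc(NC(=O)/C=C/C(C)C)c4)n2)CSCC3)c1`. It has methyl in place of hydrogen on a saturated chain carbon bound to a double-bonded chain carbon and a saturated chain carbon. In other words, ethyl becomes isopropyl at the end of the chain.

For the measured compounds named here, only one measured step is of a similar kind: methyl in place of hydrogen on a saturated chain carbon bound to a double-bonded chain carbon. That step is a 1.0-fold higher number from compound 2 to compound 3 (0.01 log units; within the scatter), so no change beyond the scatter is expected in this assay for this further methyl. A single step is thin support, so the range is kept wide. The expected step is a 1.0-fold higher number from compound 3 to compound 4 (0.01 log units; within the scatter). For compound 4 the estimated value is 25000 nM, with an expected range of 13000 nM to 48000 nM.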

Compound 4, half-maximal inhibitory concentration: 21800 nM
For compound 4 the middle estimate is 1.1-fold (0.06 log units) above the measured one; the measured number falls inside the stated range.
By their numbers in this assay, from the lowest: compounds 4, 2 and 3 (each within the scatter of the next). At a limit, above all of these: compound 1.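

In this assay the further methyl at the end of the chain cannot be told apart from the scatter: the data give a 1.1-fold lower number from compound 3 to compound 4 (0.05 log units; within the scatter) and also a 1.1-fold lower number from compound 2 to compound 4 (0.03 log units; within the scatter) for the wider change, so the methyl, ethyl and isopropyl ends all read level. For the compounds shown here, with the isopropyl end held fixed, the one step beyond the scatter lies elsewhere, on the nitrogen on an aromatic ring, where 3-methoxyphenyl replaces 1-methyl-1H-pyrazol-3-yl and the data give an at least 2.2-fold lower number from compound 1 to compound 4 (0.36 log units; beyond the scatter) for that swap. The number for compound 1 is a limit, so this step sets only a minimum size: the limit of > 50000 nM in this assay, at which 1 of the 4 values shown sits.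

The chain ends shown are all plain carbon groups, so it remains open whether a longer chain, a cyclopropyl ring or an amine at that end would also read level with these three. On these data alone, the 1-methyl-1H-pyrazol-3-yl group appears here only with the isopropyl end, so it also remains open whether the chain end would read as flat alongside that group.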